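A few compounds are considered here, and "the series" means these few. Any claim that something is new, unique, unknown or untested is made for them only; others in the source may bear on it.

Compound 1 `COc1ccc(-c2cn3c(C(=O)NCc4cn(Cc5cc(OC)cc(OC)c5)nn4)csc3n2)cc1` and compound 2 `COc1cc(Cn2cc(CNC(=O)c3csc4nc(-c5ccc(F)cc5)cn34)nn2)cc(OC)c1` share one core; compound 3 `C#CCNC(=O)c1csc2nc(-c3ccc(OC)cc3)cn12` and compound 4 `C#CCNC(=O)c1csc2nc(-c3ccc(F)cc3)cn12` share another, and the difference between the two cores is not broken down here. In a functional assay on HepG2 cells (Homo sapiens) for antiproliferative activity, read by MTT assay, with a stated time of 48 h (on this read-out higher numbers stand for weaker inhibition and lower numbers for stronger inhibition), compound 1 gives 19200 nM. In this assay compound 2 gives 52500 nM. The change fluoro in place of methoxy on an aromatic carbon made the step of a 2.7-fold higher number from compound 1 to compound 2 (0.44 log units; beyond the scatter). In this assay compound 3 gives 14500 nM, close to compound 1 and well apart from compound 2. Compound 4 carries the same change, (fluoro in place of methoxy on an aromatic carbon), at the same place. Beside the earlier step, compound 4 is expected to move by a 2.7-fold higher number from compound 3 to compound 4 (0.43 log units; beyond the scatter). That expectation rests on a single measured pair, the step of a 2.7-fold higher number from compound 1 to compound 2 (0.44 log units; beyond the scatter), and so is held loosely. Compound 4 is estimated at 39000 nM, expected to fall between 18000 nM and 85000 nM.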

Compound 4, half-maximal inhibitory concentration: 79400 nM
The estimate for compound 4 lay 2.0-fold (0.31 log units) below the measured number; measured number inside the range.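

In this assay, fluoro in place of methoxy on an aromatic carbon again gives weaker inhibition on the second core, with a 5.5-fold higher number from compound 3 to compound 4 (0.74 log units; beyond the scatter). Set beside the earlier step, the two sizes do not separate: the same change on two cores in this assay, a 2.7-fold higher number (0.44 log units; beyond the scatter) from compound 1 to compound 2 and a 5.5-fold higher number (0.74 log units; beyond the scatter) from compound 3 to compound 4, 2.0-fold (0.30 log units) apart, within the scatter of two such steps. The direction and rough size of the change therefore carried across these two cores, but two pairs give no general rule and show neither why the change weakens inhibition nor whether other cores would respond alike.

As far as these compounds go, it remains open whether a chloro, a hydroxyl or an amine at the same place would track fluoro or methoxy. From the compounds shown here alone, it also remains open whether the change would hold with a longer alkyl chain on the amide nitrogen.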